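Stepping from compound 1 to compound 4 in whole blood

A few compounds are considered here, and "the series" means these few. Any claim that something is new, unique, unknown or untested is made for them only; others in the source may bear on it.

Compound 1 `C/C(=N\OCCF)c1ccc(Sc2cc(F)cc(C3CCOCC3)c2)cc1` gives the lowest number of the three measured compounds in a functional assay (blood) for inhibition, with Homo sapiens as the target (a lower number here means a stronger inhibitor, a higher number a weaker inhibitor), at 40 nM. Compound 2 `C/C(=N\OCc1ccncc1)c1ccc(Sc2cc(F)cc(C3CCOCC3)c2)cc1` gives 300 nM and compound 3 `COC(=O)C(C)(C)CO/N=C(\C)c1ccc(Sc2cc(F)cc(C3CCOCC3)c2)cc1` gives 420 nM. Compound 4 `CS/C(=N\O)c1ccc(Sc2cc(F)cc(C3CCOCC3)c2)cc1` differs from compound 1 in one way: a group of 5 heavy atoms (2 carbon, 1 nitrogen, 1 oxygen, 1 sulfur; no ring) in place of a group of 7 heavy atoms (4 carbon, 1 nitrogen, 1 oxygen, 1 fluorine; no ring), on an aromatic carbon. The two measured steps that alter the same part of compound 1 both weakened inhibition: a 7.5-fold higher number from compound 1 to compound 2 (0.88 log units; beyond the scatter) and an 11-fold higher number from compound 1 to compound 3 (1.02 log units; beyond the scatter). Neither is the present change, yet both show that reworking this group costs activity, so a loss beyond the scatter is expected for compound 4 as well, of a size near those steps. Compound 4 is therefore estimated at 400 nM, with a range of 100 nM to 2000 nM. That estimate corresponds to an expected step of a 10-fold higher number from compound 1 to compound 4 (1.00 log units; beyond the scatter).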

Compound 4, half-maximal inhibitory concentration: 190 nM
Compound 4: the middle estimate sits 2.1-fold (0.32 log units) above what was measured, and the stated range covers the measured number.
By their numbers in this assay, from the lowest: compound 1; then compounds 4, 2 and 3 (each within the scatter of the next, the first and the last beyond it).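

The earlier steps shown here changed only the group on a saturated chain carbon bound to an oxygen, whereas this change replaces the whole group on the aromatic carbon and brings in sulfur and a hydrogen-bond donor. In this assay, it gives a 4.8-fold higher number from compound 1 to compound 4 (0.68 log units; beyond the scatter), so compound 1 remains the lowest, while compound 4 lies within the scatter of compound 2. No measurement shown accounts for this loss. On these data alone, the sulfur and the donor enter together, so their separate contributions remain open. As far as these compounds go, how an amine or a longer chain on that carbon would read also stays unknown.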